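From a Biaryl Tail to a Dimethylcarbamoyl Ethenyl Tail

The compounds below may be only part of what the source reports. "The series", "measured", "known", "first", "only" and "open" are said of these compounds alone.

Compound 2 `COC(=O)/C=C/c1cccc(N(Cc2ccc(-c3ccc(C(C)(C)C)cc3)cc2)C(=O)C2CCCCC2)c1` shows the lowest of the two numbers measured in an assay on isolated protein with Bile acid receptor (Homo sapiens) as the target (a higher number here means that more compound is needed for the effect, a lower number that less compound is needed), giving 132 nM. Its nearest neighbour, compound 1 `COC(=O)/C=C/c1cccc(N(Cc2ccc(/C=C/c3scnc3C)cc2)C(=O)C2CCCCC2)c1`, gives 227 nM in this assay. Among the measured compounds shown here, the single step between them, a 1.7-fold lower number from compound 1 to compound 2 (0.24 log units; within the scatter), lies within the scatter, so the two compounds cannot be ranked against each other. Compound 3 `COC(=O)/C=C/c1cccc(N(Cc2ccc(/C=C/C(=O)N(C)C)cc2)C(=O)C2CCCCC2)c1` has not yet been measured in this assay. It differs from compound 2 in one place: 2-(dimethylcarbamoyl)ethenyl in place of 4-(tert-butyl)phenyl on an aromatic carbon. For the measured compounds named here, no measured step covers this particular exchange; the step from compound 1 to compound 2 concerns the same place on the core but swaps a different pair of groups, and it was small. Both groups examined so far at that place carry a ring, whereas the incoming group has none, so the existing data give only weak guidance. With that caution, a modest rise is expected, as a 3.0-fold higher number from compound 2 to compound 3 (0.48 log units; beyond the scatter), though it may not clear the scatter. Compound 3 is therefore estimated at 400 nM, with a range from 130 nM to 1300 nM.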

Compound 3, half-maximal effective concentration: > 1000 nM
Compound 3 was reported as a limit (the forecaster's own chance of this, stated with the estimate: 5%); at least 2.5-fold (0.39 log units) between middle value and limit.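

Compound 3 is reported only as a limit in this assay, not as a number: the limit of > 1000 nM in this assay, at which 1 of the 3 values shown sits.

Until now this place, para to a large group, had shown no readable response, since the only step there lay within the scatter, but the new compound shows that the place is not indifferent to what it carries: an at least 7.5-fold higher number from compound 2 to compound 3 (0.87 log units; beyond the scatter). The same holds against the thiazole compound, where the ethenyl link stays and only its end group changes, with an at least 4.4-fold higher number from compound 1 to compound 3 (0.64 log units; beyond the scatter), so the ethenyl link alone does not keep the number low and the end group on it matters. Among these three compounds, the two groups with a ring give the lower numbers and the 2-(dimethylcarbamoyl)ethenyl group without a ring gives the limit, and none of the three goes against this.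

The limit leaves the true size of both rises open. From the compounds shown here alone, whether the rise follows the loss of the ring or the arrival of the dimethylcarbamoyl group also stays open, and a plain phenyl or a carboxylic acid at the end of the same ethenyl chain would help to separate the two.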